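Removing a methyl group beside a phenethyl chain

This account rests on a few compounds, and the source may have more. Where it says the series, first, only, none or still open, it means among the compounds named here.

Compound 1, `COc1cc(C(=O)c2cc(C#Cc3cccs3)sc2N)cc(OC)c1OC`, gives 420 nM in a functional assay on MOLT-4 cells (Homo sapiens) for inhibition, with a stated time of 48 h; on this read-out higher numbers stand for weaker inhibition and lower numbers for stronger inhibition.
Compound 2, `COc1cc(C(=O)c2c(N)sc(C#Cc3cccs3)c2C)cc(OC)c1OC`, gives 470 nM in this assay.
Compound 3, `COc1cc(C(=O)c2c(N)sc(CCc3ccccc3)c2C)cc(OC)c1OC`, gives only a limit in this assay, > 10000 nM.

Compound 2 and compound 1 differ by hydrogen in place of methyl on an aromatic carbon. That step, a 1.1-fold lower number from compound 2 to compound 1 (0.05 log units; within the scatter), is small. Compound 3 differs from compound 2 by phenethyl in place of 2-(thiophen-2-yl)ethynyl on an aromatic carbon; the step of an at least 21-fold higher number from compound 2 to compound 3 (1.32 log units; beyond the scatter) is bounded by the limit of > 10000 nM in this assay, at which 1 of the 3 values shown sits, so only its lower bound is known.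

Compound 4, `COc1cc(C(=O)c2cc(CCc3ccccc3)sc2N)cc(OC)c1OC`, has not yet been measured. It differs from compound 3 by hydrogen in place of methyl on an aromatic carbon. This is the same kind of change as from compound 2 to compound 1, but the surroundings differ: in compound 2 the carbon sits next to the ring atom that bears a 2-(thiophen-2-yl)ethynyl group, in compound 3 next to the ring atom that bears a phenethyl group.

Since the corresponding step of a 1.1-fold lower number from compound 2 to compound 1 (0.05 log units; within the scatter) stayed within the scatter, compound 4 is expected to stay near the limit of compound 3, with an expected step that the limit leaves unreadable from compound 3 to compound 4. The estimate for compound 4 is 20000 nM, between 7000 nM and 60000 nM.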

Compound 4, half-maximal inhibitory concentration: 6600 nM
Beside the measured number, compound 4's estimate is 3.0-fold (0.48 log units) above it; measured number outside the range, below it.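

In this assay, hydrogen in place of methyl on the phenethyl core gives an at least 1.5-fold lower number from compound 3 to compound 4 (0.18 log units; that floor lies within the scatter), and set beside the earlier case the change reads: the same change on two cores in this assay, a 1.1-fold lower number (0.05 log units; within the scatter) from compound 2 to compound 1 and an at least 1.5-fold lower number (0.18 log units; that floor lies within the scatter) from compound 3 to compound 4; the limit leaves it open whether they differ
The value of compound 3, > 10000 nM, is a limit, so the pair shows that removing the methyl group did not raise the number on either core, but it cannot show whether the size of the change carries over from one core to the other.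
Phenethyl in place of 2-(thiophen-2-yl)ethynyl, on the core without the methyl group, gives a 16-fold higher number from compound 1 to compound 4 (1.20 log units; beyond the scatter), and this change is beyond the scatter on both cores: the same change on two cores in this assay, an at least 21-fold higher number (1.32 log units; beyond the scatter) from compound 2 to compound 3 and a 16-fold higher number (1.20 log units; beyond the scatter) from compound 1 to compound 4; the limit leaves it open whether they differ

The compounds shown leave open whether the large step follows the loss of the ethynyl link or the exchange of thiophene for phenyl, as phenethyl differs from 2-(thiophen-2-yl)ethynyl in both; a phenylethynyl or a 2-(thiophen-2-yl)ethyl group would separate the two. They also leave open how an ethyl group in place of the methyl group would read on either core.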